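Swapping an amide substituent on a shared core

A few compounds are considered here, and "the series" means these few. Any claim that something is new, unique, unknown or untested is made for them only; others in the source may bear on it.

Measured so far:
compound 1, `CC(C)NC(=O)N1CCN(C(=S)SCc2cn(Cc3ccccc3F)nn2)CC1`: 7130 nM
compound 2, `CCN(C)C(=O)N1CCN(C(=S)SCc2cn(Cc3ccccc3F)nn2)CC1`: 19700 nM
compound 3, `CC(C)NC(=O)N1CCN(C(=S)SCc2cn(Cc3ccc(F)cc3)nn2)CC1`: 5970 nM

These values come from a functional assay on SMMC-7721 cells (Homo sapiens) for cytotoxicity, read by MTT assay, with a stated time of 72 h; on this read-out higher numbers stand for weaker inhibition and lower numbers for stronger inhibition. Compound 1 and compound 3 differ in their cores by 4-fluorophenyl in place of 2-fluorophenyl on a saturated chain carbon bound to an aromatic nitrogen, and this gave a 1.2-fold lower number from compound 1 to compound 3 (0.08 log units; within the scatter). Within the core of compound 1, the change ethyl(methyl)amino in place of isopropylamino on a carbonyl carbon gave a 2.8-fold higher number from compound 1 to compound 2 (0.44 log units; beyond the scatter). Compound 4, `CCN(C)C(=O)N1CCN(C(=S)SCc2cn(Cc3ccc(F)cc3)nn2)CC1`, is not yet measured; it carries the same change on the core of compound 3, namely (ethyl(methyl)amino in place of isopropylamino on a carbonyl carbon).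

Because compound 1 to compound 2 gave a 2.8-fold higher number from compound 1 to compound 2 (0.44 log units; beyond the scatter), and because the cores of compound 1 and compound 3 sit close by a 1.2-fold lower number from compound 1 to compound 3 (0.08 log units; within the scatter), a step of about the same size is expected from compound 3 to compound 4, roughly a 2.8-fold higher number from compound 3 to compound 4 (0.44 log units; beyond the scatter). Compound 4 is therefore estimated at 16500 nM in this assay, with a likely range from 8000 nM to 35000 nM.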

Compound 4, half-maximal inhibitory concentration: 23700 nM
The estimate for compound 4 lay 1.4-fold (0.16 log units) below the measured number; measured number inside the range.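

In this assay, putting ethyl(methyl)amino in place of isopropylamino on the carbonyl carbon of the core of compound 3 gave a 4.0-fold higher number from compound 3 to compound 4 (0.60 log units; beyond the scatter) and so repeated the step seen on the other core: the same change on two cores in this assay, a 2.8-fold higher number (0.44 log units; beyond the scatter) from compound 1 to compound 2 and a 4.0-fold higher number (0.60 log units; beyond the scatter) from compound 3 to compound 4, 1.4-fold (0.16 log units) apart, within the scatter of two such steps.

The move of fluorine on the phenyl ring, by contrast, gave only a 1.2-fold higher number from compound 2 to compound 4 (0.08 log units; within the scatter) and stayed small with either amide group: the same change on two cores in this assay, a 1.2-fold lower number (0.08 log units; within the scatter) from compound 1 to compound 3 and a 1.2-fold higher number (0.08 log units; within the scatter) from compound 2 to compound 4, 1.4-fold (0.16 log units) apart, within the scatter of two such steps.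

The change therefore carried over with a similar size between these two closely related cores, but this does not show why it raises the number or that it would do the same on a more distant core.

The compounds shown leave open whether the step follows the amide hydrogen, which only isopropylamino carries, or the shape of the carbon chains. Ethylamino and diethylamino on the same carbonyl carbon would help separate the two.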